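Swapping a Methyl Sulfonyl for a Methylimidazole Ring

The source may report more compounds than this note shows. Statements on the series, on what has been measured and on what is new or still open speak of the compounds shown alone.

Three compounds share one core and differ only in the group attached to the sulfonyl sulfur. Compound 1 `CS(=O)(=O)n1cc(CCCC(=O)NCCCn2ccnc2)c2ccccc21` carries a methyl there and, in an assay on isolated protein for activation of Insulin-degrading enzyme (Homo sapiens), read by fluorescence, with stated times of 10 min and 20 min (on this read-out lower numbers stand for an effect already at smaller amounts and higher numbers for an effect only at larger amounts of compound), compound 1 gives 26900 nM, the highest number of the three. Compound 2 `O=C(CCCc1cn(S(=O)(=O)c2ccccc2F)c2ccccc12)NCCCn1ccnc1` carries a 2-fluorophenyl instead, and in this assay compound 2 gives 7940 nM. Compound 3 `O=C(CCCc1cn(S(=O)(=O)c2cccc(F)c2)c2ccccc12)NCCCn1ccnc1` carries a 3-fluorophenyl, and in this assay compound 3 gives 10200 nM. The two aromatic replacements both move the number down: a 3.4-fold lower number from compound 1 to compound 2 (0.53 log units; beyond the scatter) and a 2.6-fold lower number from compound 1 to compound 3 (0.42 log units; beyond the scatter), while the two fluorophenyl compounds sit close together, a 1.3-fold higher number from compound 2 to compound 3 (0.11 log units; within the scatter).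

Compound 4 `Cn1cnc(S(=O)(=O)n2cc(CCCC(=O)NCCCn3ccnc3)c3ccccc32)c1` is the next step from compound 1: 1-methyl-1H-imidazol-4-yl in place of methyl on a sulfonyl sulfur. Like the two measured steps, it exchanges the methyl for an aromatic ring, though a smaller, five-membered one holding two nitrogens, so the earlier steps bear on it only partly. A modest lowering of the number is therefore expected, somewhat smaller than the fluorophenyl steps, a 2.1-fold lower number from compound 1 to compound 4 (0.32 log units; beyond the scatter). In this assay compound 4 is estimated at 13000 nM, with a likely range from 5500 nM to 30000 nM.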

Compound 4, half-maximal effective concentration: 28800 nM
Compound 4: the middle estimate sits 2.2-fold (0.35 log units) below what was measured; the range from low to high includes it.
By their numbers in this assay, from the lowest: compounds 2 and 3 (each within the scatter of the next); then compounds 1 and 4 (each within the scatter of the next).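

Putting an aromatic ring on the sulfonyl sulfur does not by itself lower the number: in this assay the 1-methyl-1H-imidazol-4-yl group and the methyl cannot be told apart (a 1.1-fold higher number from compound 1 to compound 4 (0.03 log units; within the scatter)). The imidazole compound also stands apart from both fluorophenyl compounds (a 2.8-fold higher number from compound 3 to compound 4 (0.45 log units; beyond the scatter); a 3.6-fold higher number from compound 2 to compound 4 (0.56 log units; beyond the scatter)), so the lowering seen so far belongs to the two fluorophenyl groups and does not extend to every aromatic ring at this position. No measurement at hand explains the gap between the five-membered ring and the fluorophenyl rings.

From the compounds shown here alone, it remains open whether fluorine matters at all, since an unsubstituted phenyl on the sulfonyl sulfur could fall with the fluorophenyl compounds or with compound 4, and a pyridine ring, six-membered like phenyl but holding a nitrogen, would help separate ring size from the presence of ring nitrogen. Also open, going by these compounds, is how simple alkyl groups behave here, for instance whether a longer chain such as propyl gives a number like that of the methyl in compound 1 or one closer to the fluorophenyl compounds.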